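The source may report more compounds than this note shows. Statements on the series, on what has been measured and on what is new or still open speak of the compounds shown alone.

Compound 1 `CNC(=O)c1cc(Oc2ccc3nc(Nc4cccc(C(C)(C)C)c4)cnc3c2)ccn1`, compound 2 `CNC(=O)c1cc(Oc2ccc3nc(Nc4cccc(Br)c4)ncc3c2)ccn1` and compound 3 `CNC(=O)c1cc(Oc2ccc3nc(Nc4cccc(C(F)(F)F)c4)ncc3c2)ccn1` share a single core and differ only in the aryl group carried on the ring nitrogen, and all three were examined in a physicochemical assay for solubility, at pH 7; on this read-out higher numbers stand for higher solubility and lower numbers for lower solubility. For compound 1 the result is a limit of the assay, < 1000 nM. For compound 2 the result is likewise a limit, < 1000 nM. For compound 3 the result is again a limit, < 1000 nM. Compound 3 therefore stands at the same limit as the other two values, (the limit of < 1000 nM in this assay, at which 3 of the 3 values shown sit). For the measured compounds named here, the only step between measured compounds, a step that the two limits leave unreadable from compound 2 to compound 3, offers no readable size. Compound 4 `CNC(=O)c1cc(Oc2ccc3nc(Nc4ccc(C(C)C)cc4)ncc3c2)ccn1` differs from compound 3 by 4-isopropylphenyl in place of 3-(trifluoromethyl)phenyl on a nitrogen on an aromatic ring. Going by the values given here, no measured step of readable size bears on this change. Compound 4 is therefore expected to remain at or near the limit, with the step that the limit leaves unreadable from compound 3 to compound 4 estimated as nothing beyond the scatter. For compound 4 the estimate in this assay is 500 nM, ranging from 100 nM to 2000 nM.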

Compound 4, solubility: < 1000 nM
Compound 4 gave a limit, no number (the forecaster's own chance of this, stated with the estimate: 75%); the middle value does not contradict the limit.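

With compound 4 also giving only a limit in this assay, neither the step from compound 2 to compound 4 nor the step from compound 3 to compound 4 can be read: the limit of < 1000 nM in this assay, at which 4 of the 4 values shown sit.

The compounds shown leave open how large any difference between these aryl groups is in this assay.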